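A few compounds are considered here, and "the series" means these few. Any claim that something is new, unique, unknown or untested is made for them only; others in the source may bear on it.

Measured so far:
- compound 1, `CC1CCN(c2c(S(=O)(=O)c3ccccc3)cnc3ccccc23)CC1`: 89.2%
- compound 2, `COc1ccc(S(=O)(=O)c2cnc3c(F)cccc3c2N2CCC(C)CC2)cc1`: 67%
- compound 3, `CC1CCN(c2c(S(=O)(=O)c3ccccc3)cnc3c(F)cccc23)CC1`: 13%

All three were tested in an assay on isolated protein for displacement of a labelled ligand from metabotropic glutamate receptor 5 (Homo sapiens), with a stated time of 60 min, tested at 1 uM; on this read-out lower numbers stand for less inhibition and higher numbers for more inhibition at the one concentration tested (going by the name of the read-out). Compound 3 stands lowest of the three numbers; the nearest is compound 2, and the furthest is compound 1. Two steps lead to compound 3. Putting fluoro in place of hydrogen on an aromatic carbon of the core gave a number 76.2 percentage points lower from compound 1 to compound 3 (beyond the scatter), and putting hydrogen in place of methoxy on the phenyl attached to the sulfonyl sulfur gave a number 54 percentage points lower from compound 2 to compound 3 (beyond the scatter). Both were large drops, so compound 3 is the weak point among the compounds measured.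

Compound 4, `CC1CCN(c2c(S(=O)(=O)c3cc(Cl)cc(Cl)c3)cnc3c(F)cccc23)CC1`, has not yet been measured. It differs from compound 3 in one place: 3,5-dichlorophenyl in place of phenyl on a sulfonyl sulfur. The step from compound 2 to compound 3 bears most closely on this change, since it also alters the phenyl on the sulfonyl sulfur and shows that a substituent there can move the number a long way. Among the measured compounds shown here, no measured step covers the dichlorophenyl itself, so the direction is uncertain, but the step is expected to be upward. Compound 4 is estimated to give 40%, within 10% to 75%, in this assay, which means an expected step of a number 27 percentage points higher from compound 3 to compound 4 (beyond the scatter).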

Compound 4, a percentage reported as inhibition, at one concentration (the size of the read-out at that concentration, not a potency): 82%
Compound 4: the middle estimate sits 42 percentage points below what was measured; measured number outside the range, above it.
By their numbers in this assay, from the lowest: compound 3; then compound 2; then compounds 4 and 1 (each within the scatter of the next).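

With the fluoro-bearing core held fixed, the phenyl on the sulfonyl sulfur turns out to be a strong control point in this assay, since 3,5-dichlorophenyl in place of phenyl gives a number 69 percentage points higher from compound 3 to compound 4 (beyond the scatter) as a large step. Until now only methoxy had shown that a substituent on this ring could lift the number, but two chlorines do so as well, and 3,5-dichlorophenyl in place of 4-methoxyphenyl adds a number 15 percentage points higher from compound 2 to compound 4 (beyond the scatter) as a more modest step, so the low number of compound 3 is not a fixed feature of the fluoro-bearing core. Nothing available bears on the reason for these rises.

Going by these compounds, it remains open whether a single chlorine would be enough, whether the chlorines must sit on these particular ring carbons, and whether 3,5-dichlorophenyl would have a similar effect on the core of compound 1, which lacks the fluoro. Also unknown is how other groups on this phenyl, such as a nitrile, a trifluoromethyl or an amine, would compare with the chlorines.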